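Fluoro for methoxy on an indole-oxadiazole pair

A few compounds are considered here, and "the series" means these few. Any claim that something is new, unique, unknown or untested is made for them only; others in the source may bear on it.

Measured so far:
compound 1 `Cc1noc(-c2cc3ccccc3[nH]2)n1` gives > 50000 nM in a functional assay on Jurkat cells (Homo sapiens) for antiproliferative activity, read by WST assay, with a stated time of 72 h (a lower number here means a stronger inhibitor, a higher number a weaker inhibitor), a limit of the assay
compound 2 `COc1ccc2[nH]c(-c3nc(C)no3)cc2c1` gives 19900 nM in this assay

Compound 1 reports only a limit, sitting at the limit of > 50000 nM in this assay, at which 1 of the 2 values shown sits. Among the measured compounds shown here, compound 2 is therefore the only compound with a numerical value in this assay, and it stands as the sole anchor here. The measured step of an at least 2.5-fold lower number from compound 1 to compound 2 (0.40 log units; beyond the scatter) came from adding a methoxy group to the shared core of compound 1.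

Compound 3 `Cc1noc(-c2cc3cc(F)ccc3[nH]2)n1` is the next compound. It differs from compound 2 by fluoro in place of methoxy on an aromatic carbon. For the measured compounds named here, only one step bears on this change, an at least 2.5-fold lower number from compound 1 to compound 2 (0.40 log units; beyond the scatter), and it shows that the methoxy group was worth at least a modest gain over hydrogen. Fluoro is neither hydrogen nor methoxy, so compound 3 is expected to land between the two, with a 1.8-fold higher number from compound 2 to compound 3 (0.25 log units; within the scatter). Compound 3 is accordingly estimated at 35000 nM, with a range from 12000 nM to 100000 nM.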

Compound 3, half-maximal inhibitory concentration: 22900 nM
Estimate against measurement, compound 3: 1.5-fold (0.18 log units) above; the measured number falls inside the stated range.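

At this aromatic carbon, fluoro serves as well as methoxy in this assay: the exchange gives a 1.2-fold higher number from compound 2 to compound 3 (0.06 log units; within the scatter). Fluoro in place of hydrogen gives an at least 2.1-fold lower number from compound 1 to compound 3 (0.33 log units; beyond the scatter), so the gain over hydrogen is no longer tied to methoxy alone and now appears with two different groups, one with an oxygen and one without. The full size of both gains stays unknown because compound 1 gives a limit and not a number: the limit of > 50000 nM in this assay, at which 1 of the 3 values shown sits.

The compounds shown leave open whether an amine, a carboxylic acid or a longer chain on this carbon would move the number beyond the scatter of compound 2 and compound 3. They also leave open whether methoxy or fluoro would give a similar result on another aromatic carbon of the shared core.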